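Amide to Urea Swap and Cell Growth Inhibition

The source may report more compounds than this note shows. Statements on the series, on what has been measured and on what is new or still open speak of the compounds shown alone.

The measured compounds, each with its result in a functional assay on IGROV-1 cells (Homo sapiens) for inhibition, read by sulforhodamine B assay, with a stated time of 48 h; on this read-out higher numbers stand for weaker inhibition of growth and lower numbers for stronger inhibition of growth:
compound 1, `O=C(Nc1cccc(-n2cc(-c3ccncc3)c(-c3ccc(Cl)c(O)c3)n2)c1)Nc1ccc(Cl)c(Cl)c1`, gives > 32500 nM, which is a limit of the assay and not a number.
compound 2, `COc1cc(-c2nn(-c3cccc(NC(=O)c4ccc(Cl)c(C(F)(F)F)c4)c3)cc2-c2ccncc2)ccc1Cl`, gives > 32500 nM, again a limit and not a number.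
compound 3, `O=C(Nc1cccc(-n2cc(-c3ccncc3)c(-c3ccc(Cl)c(O)c3)n2)c1)Nc1cc(C(F)(F)F)cc(C(F)(F)F)c1`, gives 3550 nM.

Compound 2 therefore stands at the limit, not at a measured number, and the limit of > 32500 nM in this assay, at which 2 of the 3 values shown sit, shows that it shares this position with one other compound; only compound 3 yields a number below it. Compound 4, `COc1cc(-c2nn(-c3cccc(NC(=O)Nc4cccc(C(F)(F)F)c4)c3)cc2-c2ccncc2)ccc1Cl`, has not been measured. It differs from compound 2 in one place: (3-(trifluoromethyl)phenyl)amino in place of 4-chloro-3-(trifluoromethyl)phenyl on a carbonyl carbon. The carbonyl thus becomes part of a urea rather than an amide, and the new group carries one hydrogen-bond donor where the old one had none. Among the measured compounds shown here, since no step between two measured compounds is available, the size of the change can only be guessed. The urea compound 3 gives a number while the urea compound 1 sits at the limit, so ureas here can fall on either side. A modest gain in growth inhibition for compound 4 is expected, because compound 3 gives 3550 nM. Compound 4 is estimated at 15000 nM, within 3000 nM to 32500 nM, which means an expected step of an at least 2.1-fold lower number from compound 2 to compound 4 (0.33 log units; beyond the scatter).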

Compound 4, concentration for total growth inhibition: 3110 nM
Compound 4: middle estimate off by 4.8-fold (0.68 log units), on the high side; measured number inside the range.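

In this assay, the change on the carbonyl carbon gives an at least 10-fold lower number from compound 2 to compound 4 (1.01 log units; beyond the scatter). Among the compounds shown here, this is the first step in the set between two compounds that differ in one place, and it shows that the group at this position can carry a compound from the limit of the assay to a measured number, with a large step that lies beyond the usual scatter. The value of compound 2 is a limit and not a number, so the step has a lower bound only and its full size stays unknown: the limit of > 32500 nM in this assay, at which 2 of the 4 values shown sit.

The compounds shown leave open which part of the change matters, since the step from 4-chloro-3-(trifluoromethyl)phenyl to (3-(trifluoromethyl)phenyl)amino both brings in the nitrogen that turns the amide into a urea and removes the chlorine, and no cause for the gain can be read from these data. Separating the two parts would take a urea bearing (4-chloro-3-(trifluoromethyl)phenyl)amino on the same carbonyl carbon, and (3-(trifluoromethyl)phenyl)methyl at that place would test whether the nitrogen itself is needed.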